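The source may hold more compounds than are shown below. What is called first, only, known or untested is meant among the compounds shown, and "the series" means these compounds.

The series shares the core of compound 1 `O=C(CCc1ccc(Cl)cc1)C(=O)N1CCCCC1`. In an assay on HEK-293T cells for inhibition of phospholipase A and acyltransferase 5 (Homo sapiens), with stated times of 30 min and 20 min (on this read-out higher numbers stand for weaker inhibition and lower numbers for stronger inhibition), compound 1 gives > 10000 nM, which is a limit of the assay rather than a number. Compound 2 `O=C(CCc1ccc(Cl)cc1)C(=O)N1CCOCC1` likewise returns only a limit, > 10000 nM. Compound 3 `O=C(CCc1ccc(Cl)cc1)C(=O)N1CCCC1` also stays at a limit, > 10000 nM. Accordingly the change a step that the two limits leave unreadable from compound 1 to compound 2 cannot be sized, nor can a step that the two limits leave unreadable from compound 1 to compound 3 or a step that the two limits leave unreadable from compound 2 to compound 3, because of the limit of > 10000 nM in this assay, at which 3 of the 3 values shown sit. Compound 4 `O=C(CCc1ccc(Cl)cc1)C(=O)N1CCCC[C@H]1c1ccccc1` carries phenyl in place of hydrogen on a saturated ring carbon. Among the compounds with values here, no measured step bears on this change: all three ring variations ended at the same limit, so neither the size nor the direction of the coming step can be read from the numbers at hand. Compound 4 is estimated at 3000 nM, between 300 nM and 20000 nM, which would mean an expected step of an at least 3.3-fold lower number from compound 1 to compound 4 (0.52 log units; beyond the scatter).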

Compound 4, half-maximal inhibitory concentration: > 10000 nM
Compound 4 gave a limit, no number (the forecaster's own chance of this, stated with the estimate: 40%); middle value at least 3.3-fold (0.52 log units) away from the limit.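

Within the data shown here, compound 4 also ends at a limit, so no step from compound 1 to compound 4 can be read: the limit of > 10000 nM in this assay, at which 4 of the 4 values shown sit. The compounds shown leave open which change to the shared core, if any, would give a measurable number in this assay.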